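Swapping a furan for an ethyl on an aryl amine

The compounds below may be only part of what the source reports. "The series", "measured", "known", "first", "only" and "open" are said of these compounds alone.

Measured compounds:
- compound 1 `CCN(Cc1cccc(Br)c1)c1ccc(C(=O)N2CCc3ccc(OS(N)(=O)=O)cc3C2)cc1`: 80.2%
- compound 2 `NS(=O)(=O)Oc1ccc2c(c1)CN(C(=O)c1cccc(N(Cc3ccccc3)Cc3ccco3)c1)CC2`: 27.5%
- compound 3 `CCCN(CCC)c1ccc(C(=O)N2CCc3ccc(OS(N)(=O)=O)cc3C2)cc1`: 36.6%

In an assay on HEK293 cells for inhibition of Steryl-sulfatase (Homo sapiens), tested at 0.1 uM (a higher number here means a stronger effect of the compound at the concentration tested, a lower number a weaker effect), compound 2 gives the lowest of the three numbers; its gap to compound 3 lies within the scatter, its gap to compound 1 beyond it. Compound 4 `CCCN(Cc1ccccc1)c1cccc(C(=O)N2CCc3ccc(OS(N)(=O)=O)cc3C2)c1` differs from compound 2 by ethyl in place of furan-2-yl on a saturated chain carbon bound to a nitrogen on an aromatic ring. Within the data shown here, no measured step covers this exact change. Among the measured compounds shown here, the only measured step, a number 43.6 percentage points lower from compound 1 to compound 3 (beyond the scatter), concerns a different change at the amine and shows that this region can move the read-out strongly, in either direction for all the data say. A step within the scatter is therefore expected, a number 7.5 percentage points higher from compound 2 to compound 4 (within the scatter), with wide uncertainty. Compound 4 is estimated at 35%, between 10% and 65%.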

Compound 4, a percentage reported as inhibition, at one concentration (the size of the read-out at that concentration, not a potency): 23.1%
For compound 4 the middle estimate is 11.9 percentage points above the measured one; low and high end bracket the measured number.
By their numbers in this assay, from the lowest: compounds 4, 2 and 3 (each within the scatter of the next, the first and the last beyond it); then compound 1.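

In this assay, putting ethyl in place of furan-2-yl gives a number 4.4 percentage points lower from compound 2 to compound 4 (within the scatter), so at this saturated chain carbon bound to a nitrogen on an aromatic ring, the read-out does not separate the aromatic ring from the short chain. The amine region can still move the read-out strongly, as a number 43.6 percentage points lower from compound 1 to compound 3 (beyond the scatter) shows, but this particular change does not. No measurement available here explains why these two groups read alike.

From the compounds shown here alone, whether a carboxylic acid, an amine or a longer chain such as butyl at this place would shift the number remains open.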